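Alkoxymethylamino series: chain extension from compound 2 to compound 3

A few compounds are considered here, and "the series" means these few. Any claim that something is new, unique, unknown or untested is made for them only; others in the source may bear on it.

Measured so far in a functional assay on PC-3 cells (Homo sapiens) for cytotoxicity, read by MTT assay, with a stated time of 72 h; on this read-out higher numbers stand for weaker inhibition and lower numbers for stronger inhibition:
compound 1, `COc1ccc(COCNc2n[n+]([O-])c3ccccc3[n+]2[O-])cc1`, gives 14500 nM
compound 2, `CCOCNc1n[n+]([O-])c2ccccc2[n+]1[O-]`, gives 15900 nM

Among the compounds with values here, compound 2 and compound 1 lie within the scatter of each other in this assay, the step of a 1.1-fold higher number from compound 1 to compound 2 (0.04 log units; within the scatter) being the only measured comparison. That step replaces the 4-methoxyphenyl with methyl at the same place and leaves the number essentially unchanged, so the part of the molecule beyond the oxygen on the saturated carbon has shown no measurable influence so far.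

Compound 3, `CCCCCCCOCNc1n[n+]([O-])c2ccccc2[n+]1[O-]`, differs from compound 2 by pentyl in place of hydrogen on a saturated chain carbon, two bonds along the chain from an oxygen on a saturated carbon. Within the data shown here, no measured step touches this exact change; the one available step, from compound 1 to compound 2, is the nearest analogy and was within the scatter. On that basis the step of a 1.3-fold lower number from compound 2 to compound 3 (0.12 log units; within the scatter) is expected to stay within the scatter as well. For compound 3 in this assay the estimate is 12000 nM, with a range from 5000 nM to 30000 nM.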

Compound 3, half-maximal inhibitory concentration: 1210 nM
Estimate against measurement, compound 3: 9.9-fold (1.00 log units) above, outside the stated range (below it).
By their numbers in this assay, from the lowest: compound 3; then compounds 1 and 2 (each within the scatter of the next).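

In this assay, pentyl in place of hydrogen on a saturated chain carbon, two bonds along the chain from an oxygen on a saturated carbon, gives a 13-fold lower number from compound 2 to compound 3 (1.12 log units; beyond the scatter) and so shows that the group beyond this oxygen can move the number, which the earlier pair, compound 1 and compound 2, did not show. Hexyl in place of 4-methoxyphenyl gives a 12-fold lower number from compound 1 to compound 3 (1.08 log units; beyond the scatter) as well, so the large step appears with the heptyl chain of compound 3 and not with the 4-methoxyphenyl end of compound 1. No measured evidence bears on the reason for this step.

With only ethyl and heptyl chains shown, it remains open whether the number falls steadily with chain length, as a butyl or pentyl chain would show, or continues falling with a longer chain such as decyl. Also open, from the compounds shown here alone, is whether a terminal amine or carboxylic acid on the heptyl chain would keep this level.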